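Swapping the ether group of compound 1 for oxan-4-yl

A few compounds are considered here, and "the series" means these few. Any claim that something is new, unique, unknown or untested is made for them only; others in the source may bear on it.

Measured so far in an ADME assay on MT4 cells (Homo sapiens) for cytotoxicity, with a stated time of 5 days; on this read-out higher numbers stand for lower toxicity in this test and lower numbers for higher toxicity in this test:
compound 1 `CC(C)(C)C#Cc1cc(N(C(=O)[C@H]2CC[C@H](C)CC2)[C@H]2CC[C@H](Oc3ccc4nccn4n3)CC2)c(C(=O)O)s1`: > 20000 nM
compound 2 `CC(C)(C)C#Cc1cc(N(C(=O)[C@H]2CC[C@H](C)CC2)[C@H]2CC[C@](O)(CO[C@H]3CCOC3)CC2)c(C(=O)O)s1`: > 20000 nM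
compound 3 `CC(C)N(c1cc(C#CC(C)(C)C)sc1C(=O)O)C(=O)[C@H]1CC[C@H](C)CC1`: > 20000 nM

All three entries are limits of the assay and not numbers. Compound 1 stands at > 20000 nM, which is a limit. Compound 2 and compound 3 give no separate numbers either, as seen in the limit of > 20000 nM in this assay, at which 3 of the 3 values shown sit. Going by the values given here, no measured pair differs in one place only, so the series offers no measured step size.

Compound 4 `CC(C)(C)C#Cc1cc(N(C(=O)[C@H]2CC[C@H](C)CC2)[C@H]2CC[C@H](OC3CCOCC3)CC2)c(C(=O)O)s1` has not yet been measured. Its change from compound 1 is a group of 6 heavy atoms (5 carbon, 1 oxygen; one six-membered non-aromatic ring with 1 hetero atom) in place of a group of 9 heavy atoms (6 carbon, 3 nitrogen; one five-membered aromatic ring with 2 hetero atoms, one six-membered aromatic ring with 2 hetero atoms), on an oxygen on a saturated carbon, with oxan-4-yl entering on an oxygen on a saturated carbon.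

With compound 1, compound 2 and compound 3 all at the limit of > 20000 nM in this assay, at which 3 of the 3 values shown sit, no step beyond the usual scatter is expected in this assay. The estimated step is a number no higher from compound 1 to compound 4 (the limit leaves the size open). For compound 4 the expected value is 20000 nM, with an estimated range of 12000 nM to 30000 nM.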

Compound 4, half-maximal cytotoxic concentration: > 20000 nM
Compound 4: a limit, no number; the forecaster's own chance of this, stated with the estimate: 85%; the middle value sits exactly at the limit.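

In this assay, compound 1 and compound 4 both give only a limit, so no step can be read between them: the limit of > 20000 nM in this assay, at which 4 of the 4 values shown sit.

The compounds shown leave open where the true cytotoxic concentration of any of them lies, and whether the swap to oxan-4-yl changes it at all.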